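The compounds below may be only part of what the source reports. "The series", "measured", "known", "first", "only" and "open" are said of these compounds alone.

In a functional assay on MDA-MB-231 cells (Homo sapiens) for inhibition, read by sulforhodamine B assay, tested at 10 uM (on this read-out higher numbers stand for more inhibition at the one concentration tested (going by the name of the read-out) and lower numbers for less inhibition), compound 2 `CN(C)c1ccc(C2CC(c3ccc(-n4ccnc4)cc3)=NN2S(C)(=O)=O)cc1` gives 12%. Among the compounds with values here, the only other measured compound is compound 1 `C=C(C)C(=O)N1N=C(c2ccc(-n3ccnc3)cc2)CC1c1ccc(N(C)C)cc1`, which in this assay gives 4.3%; the step of a number 7.7 percentage points higher from compound 1 to compound 2 (within the scatter) lies within the scatter, so the two compounds cannot be told apart on this read-out, and compound 2 has no measured neighbour that stands apart from it.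

Compound 3 `CN(C)c1ccc(C2CC(c3ccc(-n4ccnc4)cc3)=NN2S(=O)(=O)c2ccc([N+](=O)[O-])cc2)cc1` has not yet been tested. It differs from compound 2 by 4-nitrophenyl in place of methyl on a sulfonyl sulfur. Within the data shown here, no measured step touches this position: the single step known, from compound 1 to compound 2, concerns the group on the ring nitrogen, not the group on the sulfonyl sulfur, and it was itself within the scatter. The account therefore offers no basis for a step beyond the scatter in either direction in this assay, and the step of a number 3 percentage points higher from compound 2 to compound 3 (within the scatter) is expected to be small. Compound 3 is estimated to give 15% in this assay, within a range from 0% to 40%.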

Compound 3, a percentage reported as inhibition, at one concentration (the size of the read-out at that concentration, not a potency): 41.5%
Compound 3: middle estimate off by 26.5 percentage points, on the low side; the whole stated range lies below it.
By their numbers in this assay, from the lowest: compounds 1 and 2 (each within the scatter of the next); then compound 3.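

Within the data shown here, the group on the sulfonyl sulfur proves able to move the number: in this assay the step of a number 29.5 percentage points higher from compound 2 to compound 3 (beyond the scatter) is the first to stand clear of the scatter, at a position that no earlier step had touched. Among these compounds, the step of a number 37.2 percentage points higher from compound 1 to compound 3 (beyond the scatter) shows that the group on the amine nitrogen in the ring can separate compounds when it is (4-nitrophenyl)sulfonyl, although methylsulfonyl in that place gave only the step of a number 7.7 percentage points higher from compound 1 to compound 2 (within the scatter) and could not be told apart from (1-methylethenyl)carbonyl. Nothing available explains the rise.

The compounds shown do not tell whether the number goes with the added benzene ring or with its nitro group, so a plain phenyl, a 4-aminophenyl or a 4-methoxyphenyl on the sulfonyl sulfur remains an open case. On these data alone, with one concentration only, how potent compound 3 is also remains open.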